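The source may hold more compounds than are shown below. What is called first, only, known or untested is meant among the compounds shown, and "the series" means these compounds.

Measured so far in a functional assay on the whole organism (strain Wistar) with Rattus norvegicus as the target, read by paw edema (a lower number here means that less compound is needed, a higher number that more compound is needed for the effect), for two compounds
Compound 1 (`CCC(=O)NS(=O)(=O)c1ccc(-n2nc(C(F)(F)F)cc2-c2ccc(Br)cc2)cc1CO`) 7.2 mg/kg
Compound 2 (`CCC(=O)NS(=O)(=O)c1ccc(-n2nc(C(F)F)cc2-c2ccc(Br)cc2)cc1CO`) 5.6 mg/kg

Compound 1 stands at 7.2 mg/kg and has only compound 2 for comparison. The gap between them is a 1.3-fold lower number from compound 1 to compound 2 (0.11 log units; within the scatter) and so the two cannot be told apart.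

Compound 3 (`CCC(=O)NS(=O)(=O)c1ccc(-n2nc(C(F)(F)F)cc2-c2ccc(OC)c(C)c2)cc1CO`) has not been measured yet. It keeps the core of compound 1 and exchanges one group. The change is 4-methoxy-3-methylphenyl in place of 4-bromophenyl on an aromatic carbon and it sits on an aromatic carbon of a five-membered aromatic ring with 2 nitrogen.

Among the compounds with values here, the only measured step lies at a different place, on the trifluoromethyl group. Compound 2 shows a 1.3-fold lower number from compound 1 to compound 2 (0.11 log units; within the scatter) at that place and so says little about the 4-bromophenyl group. Within the data shown here, no measured compound varies that group, which leaves the data without a direction for this change. The expected result in this assay is therefore no clear shift, with a wide margin, since a whole group is replaced. The estimated change is a 1.0-fold higher number from compound 1 to compound 3 (0.02 log units; within the scatter) and neither direction is favoured. For compound 3 the estimated value is 7.5 mg/kg with an expected range of 2.8 mg/kg to 20 mg/kg in this read-out.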

Compound 3, dose for half-maximal effect: 6.2 mg/kg
For compound 3 the middle estimate is 1.2-fold (0.08 log units) above the measured one; measured number inside the range.
By their numbers in this assay, from the lowest: compounds 2, 3 and 1 (each within the scatter of the next).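

Within the data shown here, this is the first view of the position held by the 4-bromophenyl group on the five-membered aromatic ring with 2 nitrogen. In this assay the exchange for 4-methoxy-3-methylphenyl gives a 1.2-fold lower number from compound 1 to compound 3 (0.06 log units; within the scatter) and so the two compounds cannot be told apart. The position therefore tolerates a replacement that loses the bromine, grows from 7 to 9 heavy atoms and brings in a hydrogen-bond acceptor, with no readable difference in this whole-animal read-out, and nothing available gives a reason for that outcome.

Among the compounds shown, the methoxy and methyl groups arrive together, so what each contributes alone remains open, as does whether the bromine itself matters. Also open, from the compounds shown here alone, is whether a group of a quite different kind on this phenyl ring, such as a carboxylic acid or an amine, would shift the dose needed by more than the usual scatter of the assay.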